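Chloro for methoxymethyl on the aryl ring of compound 1

This account rests on a few compounds, and the source may have more. Where it says the series, first, only, none or still open, it means among the compounds named here.

Compound 1 `COCc1ccccc1C1Cc2nccn2C1` has been tested in a functional assay on CHO cells for agonist activity at Alpha-1D adrenergic receptor (Homo sapiens), read by FLIPR and calcium flux; on this read-out higher numbers stand for an effect only at larger amounts of compound and lower numbers for an effect already at smaller amounts. In this assay compound 1 gives only the limit of the assay, > 10000 nM, and no number. Compound 2 `c1ccc(C2CCc3nc[nH]c3C2)cc1` likewise gives only a limit in this assay, > 10000 nM; > 10000 nM; > 10000 nM (3 entries). Compound 3 `Clc1cccc(C2CCc3nc[nH]c3C2)c1` also gives only a limit in this assay, > 10000 nM. So compound 1 sits where every value shown sits, at the limit (the limit of > 10000 nM in this assay, at which 2 of the 3 values shown sit); no step between measured compounds can be stated, and no compound can be set above or below another on these numbers.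

The next compound, compound 4 `Clc1ccccc1C1Cc2nccn2C1`, carries chloro in place of methoxymethyl on an aromatic carbon; it is not yet measured in this assay. For the measured compounds named here, with every value so far being a limit, no size of step beyond the scatter is expected in either direction. Compound 4 is therefore estimated to give about 15000 nM in this assay, in a range from 5000 nM to 50000 nM, most likely again reported only as a limit. The estimated step that the limit leaves unreadable from compound 1 to compound 4 is expected to stay within the scatter.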

Compound 4, half-maximal effective concentration: 364 nM
Beside the measured number, compound 4's estimate is 41-fold (1.61 log units) above it; measured number below the stated range.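

Chloro in place of methoxymethyl on this aromatic carbon gives an at least 27-fold lower number from compound 1 to compound 4 (1.43 log units; beyond the scatter) in this assay, the first step of the series that can be read and the first sign that this place on the ring of the core of compound 1 bears on the read-out. The size of this step is only a bound, because compound 1 gives a limit and not a number: the limit of > 10000 nM in this assay, at which 2 of the 4 values shown sit.

What leaves is a group of 3 heavy atoms with 1 hydrogen-bond acceptor and what enters is a single chlorine atom, and one pair cannot tell which of these differences carries the step. Open, as far as these compounds go, is whether fluoro, methyl or methoxy on the same aromatic carbon would give a number like that of compound 4. Also open, from the compounds shown here alone, is how the unsubstituted ring on the core of compound 1 would read.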